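Cyclopentylsulfanyl for pyrrolidinyl on a non-toxic core

This account rests on a few compounds, and the source may have more. Where it says the series, first, only, none or still open, it means among the compounds named here.

Compound 2 `Nc1nc(N2CCCC2)c2ncn(/C=C3/CC3(CO)CO)c2n1` shares its core with compound 1 `CC(C)Nc1nc(N)nc2c1ncn2/C=C1/CC1(CO)CO`, the two differing only at one aromatic carbon. In an ADME assay on CCRF-HSB-2 cells (Homo sapiens) for cytotoxicity, with a stated time of 7 days (on this read-out lower numbers stand for higher toxicity in this test and higher numbers for lower toxicity in this test), compound 1 gives > 20000 nM, which is a limit of the assay and not a number. In this assay compound 2 also reaches only a limit, > 20000 nM. The step that the two limits leave unreadable from compound 1 to compound 2 therefore cannot be read, since both ends sit at the limit; the whole picture so far is the limit of > 20000 nM in this assay, at which 2 of the 2 values shown sit, and compound 2 stands there with no number of its own.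

Compound 3 `Nc1nc(SC2CCCC2)c2ncn(/C=C3/CC3(CO)CO)c2n1` is the next member. Its change from compound 2 is cyclopentylsulfanyl in place of pyrrolidin-1-yl on an aromatic carbon. For the measured compounds named here, only the step from compound 1 to compound 2 touches the same aromatic carbon, and its size is unreadable, so no measured step gives a direction for compound 3 in this assay. Compound 3 is expected to stay at the limit, with a step that the limit leaves unreadable from compound 2 to compound 3 that is estimated to be nil beyond the scatter. For compound 3 the estimate in this assay is 30000 nM, within 10000 nM to 100000 nM.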

Compound 3, half-maximal cytotoxic concentration: 91000 nM
Compound 3: the middle estimate sits 3.0-fold (0.48 log units) below what was measured; measured number inside the range.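

Neither step to compound 3, from compound 1 or from compound 2, can be read, and the picture in this assay remains: the limit of > 20000 nM in this assay, at which 2 of the 3 values shown sit. The compounds shown leave open whether cyclopentylsulfanyl, pyrrolidin-1-yl or isopropylamino on this aromatic carbon changes the cytotoxicity read-out at all.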